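This account rests on a few compounds, and the source may have more. Where it says the series, first, only, none or still open, it means among the compounds named here.

Measured so far:
compound 1, `COc1ccc2c(c1)C(C)=CC(C)(C)N2Cc1cn(Cc2cc3cc(OC)ccc3nc2Cl)nn1` — 26400 nM
compound 2, `CC1=CC(C)(C)N(Cc2cn(Cc3cc4ccccc4nc3Cl)nn2)c2ccccc21` — 16200 nM

In a functional assay on MCF7 cells (Homo sapiens) for cytotoxicity, read by MTT assay, with a stated time of 48 h (a higher number here means a weaker inhibitor, a lower number a stronger inhibitor), compound 1 has the highest number of the two measured compounds, with compound 2 the nearest to it, though the gap between the two lies within the usual scatter of this kind of measurement. Compound 3, `COc1ccc2nc(Cl)c(Cn3cc(CN4c5ccc(C)cc5C(C)=CC4(C)C)nn3)cc2c1`, differs from compound 1 in one place: methyl in place of methoxy on an aromatic carbon, on the shared core. For the measured compounds named here, no measured pair shows what this change does here, so the expected step in this assay from compound 1 to compound 3 is none beyond the scatter, in either direction. Compound 3 is therefore estimated at 25000 nM, within a range of 10000 nM to 60000 nM, a step of a 1.1-fold lower number from compound 1 to compound 3 (0.02 log units; within the scatter).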

Compound 3, half-maximal inhibitory concentration: 14300 nM
Estimate against measurement, compound 3: 1.7-fold (0.24 log units) above; measured number inside the range.
By their numbers in this assay, from the lowest: compounds 3, 2 and 1 (each within the scatter of the next).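

In this assay methyl in place of methoxy on an aromatic carbon of the shared core gives a 1.8-fold lower number from compound 1 to compound 3 (0.27 log units; within the scatter) so this first readable change at this position does not separate the two compounds. At this carbon, methoxy and methyl cannot be told apart in this measurement. No measurement available here bears on the reason for this result. From the compounds shown here alone, what stays open is whether an amine, a carboxylic acid or a longer chain on this carbon would give a step beyond the scatter.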